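Fluoro-to-chloro swap on the aryl group of the shared core

The source may hold more compounds than are shown below. What is called first, only, known or untested is meant among the compounds shown, and "the series" means these compounds.

Two compounds of this series have been run in an assay on isolated protein for inhibition of glucose-6-phosphatase catalytic subunit 1 (Homo sapiens), read by inositol phosphate accumulation, with a stated time of 30 min, tested at 100 uM; a higher number here means more inhibition at the concentration tested (going by the name of the read-out), a lower number less inhibition. Compound 1 `CCOC(=O)C1=CC(c2ccccc2)C2=C(CC(C)(C)CC2=O)N1` was reported in this assay as "not active" (no number reported), with no number given. For the measured compounds named here, compound 2 `CC1(C)CC(=O)c2c(-c3ccc(F)cc3)cc(-c3ccccc3)nc2C1` gives in this assay 11.1%, which is the only number so far in the set; compound 2 therefore stands as the sole measured point, and no comparison of sizes between measured compounds is available.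

Compound 3 `CC1(C)CC(=O)c2c(-c3ccc(Cl)cc3)cc(-c3ccccc3)nc2C1` is the next entry to be measured in this assay. It differs from compound 2 as chloro in place of fluoro on an aromatic carbon. Going by the values given here, since no step between measured compounds exists to guide the size of this change, the expected step from compound 2 to compound 3 is small, without a clear direction, and likely within the usual scatter of the assay, as a number 1.9 percentage points higher from compound 2 to compound 3 (within the scatter). Compound 3 is estimated at 13% in this assay, with an expected range from 0% to 30%.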

Compound 3, a percentage reported as inhibition, at one concentration (the size of the read-out at that concentration, not a potency): 11.3%
Compound 3: the middle estimate sits 1.7 percentage points above what was measured; the measured number falls inside the stated range.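

In this assay, the swap of 4-fluorophenyl to 4-chlorophenyl on the shared core reads as a number 0.2 percentage points higher from compound 2 to compound 3 (within the scatter). For the compounds shown here, this is the first step that can be read, and at this place, on an aromatic carbon para to a large group, the read-out does not tell chloro from fluoro. No data given here bear on the reason for this result.

On these data alone, the two halogens alone do not show whether this position can influence the read-out, so it remains open whether an amine, a carboxylic acid or a longer chain in the same place would separate from compound 2. Compound 1 differs from compound 2 in more than one place, which leaves open what part of the shared core matters for the read-out.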